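The compounds below may be only part of what the source reports. "The series", "measured", "known", "first", "only" and "open" are said of these compounds alone.

Four compounds share one core and differ at two places. Compound 1 `CCCCCCCCCCC#Cc1cc2cn(C)c(=O)nc2o1` carries a methyl on an aromatic nitrogen and a long chain that ends in a triple bond. Compound 2 `CCCCCCCCCCC#Cc1cc2cn([C@@H]3O[C@H](CO)[C@@H](O)[C@@H]3O)c(=O)nc2o1` carries a 3,4-dihydroxy-5-(hydroxymethyl)oxolan-2-yl group on that nitrogen instead. Compound 3 `CCCCCCC#Cc1cc2cn([C@@H]3O[C@H](CO)[C@@H](O)[C@@H]3O)c(=O)nc2o1` keeps that group but has a shorter chain, and compound 4 `CCCCCCC#Cc1cc2cn(C)c(=O)nc2o1` joins the methyl with the shorter chain; compound 4 has not been measured.

In a functional assay on HEL cells (Homo sapiens) for cytotoxicity (a lower number here means that less compound is tolerated, a higher number that more compound is tolerated), compound 2 gives 46000 nM. Compound 3 gives 133000 nM in this assay. For compound 1 this assay reports only a limit, > 150000 nM, and no number.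

The two cores differ by hydrogen in place of butyl on a saturated chain carbon, six bonds along the chain from a triple-bonded carbon, a change that gives a 2.9-fold higher number from compound 2 to compound 3 (0.46 log units; beyond the scatter). The exchange on the nitrogen, (methyl in place of 3,4-dihydroxy-5-(hydroxymethyl)oxolan-2-yl on an aromatic nitrogen), gives an at least 3.2-fold higher number from compound 2 to compound 1 (0.51 log units; beyond the scatter), and its full size is not known, since compound 1 sits at the limit of > 150000 nM in this assay, at which 1 of the 3 values shown sits.

From compound 3 to compound 4 the change is methyl in place of 3,4-dihydroxy-5-(hydroxymethyl)oxolan-2-yl on an aromatic nitrogen, the same change as from compound 2 to compound 1, with the same surroundings word for word. The expected step is a 2.6-fold higher number from compound 3 to compound 4 (0.42 log units; beyond the scatter), resting on compound 2 and compound 1 with an at least 3.2-fold higher number from compound 2 to compound 1 (0.51 log units; beyond the scatter). Because compound 1 sits at the limit of > 150000 nM in this assay, at which 1 of the 3 values shown sits, a second limit rather than a number is the likely outcome for compound 4. The estimate for compound 4 in this assay is 350000 nM, expected to lie between 130000 nM and 1000000 nM.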

Compound 4, minimum cytotoxic concentration: 194000 nM
For compound 4 the middle estimate is 1.8-fold (0.26 log units) above the measured one, within the range that was stated.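

In this assay, exchanging the 3,4-dihydroxy-5-(hydroxymethyl)oxolan-2-yl group for methyl on the shorter-chain core gives a 1.5-fold higher number from compound 3 to compound 4 (0.16 log units; within the scatter), so compound 3 and compound 4 cannot be told apart in this read-out. Set beside the same exchange on the longer-chain core, this result does not settle whether the change carries over unchanged: the same change on two cores in this assay, an at least 3.2-fold higher number (0.51 log units; beyond the scatter) from compound 2 to compound 1 and a 1.5-fold higher number (0.16 log units; within the scatter) from compound 3 to compound 4; the limit leaves it open whether they differ Compound 1 gives only a limit, > 150000 nM, and not a number, so the step from compound 1 to compound 4 cannot be read, and the series shows neither that the exchange has the same size on both cores nor that its size depends on the chain.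

The compounds shown leave open how large the exchange really is on the longer-chain core, and whether a chain of another length, shorter than that of compound 3 or longer than that of compound 1, would give the same picture in this assay. They also leave open what other groups on the aromatic nitrogen, such as an ethyl group or a short chain ending in an amine, would give on either core.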